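Aryl variation on the shared core: estimate for compound 4

This account rests on a few compounds, and the source may have more. Where it says the series, first, only, none or still open, it means among the compounds named here.

Measured compounds in a functional assay on CCRF-CEM cells (Homo sapiens) for antiproliferative activity, with a stated time of 72 h; a lower number here means a stronger inhibitor, a higher number a weaker inhibitor:
- compound 1, `OC[C@H]1O[C@@H](n2cnc3c(NCc4ccc(Cl)c(Cl)c4)ncnc32)[C@H](O)[C@@H]1O`, gives 3800 nM.
- compound 2, `COc1cc(CNc2ncnc3c2ncn3[C@@H]2O[C@H](CO)[C@@H](O)[C@H]2O)cc(OC)c1`, gives > 166000 nM; this is a limit of the assay, not a number.
- compound 3, `OC[C@H]1O[C@@H](n2cnc3c(NCc4ccc(F)c(F)c4F)ncnc32)[C@H](O)[C@@H]1O`, gives 58200 nM.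

Compound 3 holds the highest of the two numbers shown; its nearest neighbour is compound 1, and the step of a 15-fold higher number from compound 1 to compound 3 (1.19 log units; beyond the scatter) is large. Against compound 2 only a limit stands, (the limit of > 166000 nM in this assay, at which 1 of the 3 values shown sits), and the step of an at least 2.8-fold lower number from compound 2 to compound 3 (0.45 log units; beyond the scatter) reads as at least modest. The step of an at least 43-fold higher number from compound 1 to compound 2 (1.64 log units; beyond the scatter) is the largest shown.

Compound 4, `COc1cccc(CNc2ncnc3c2ncn3[C@@H]2O[C@H](CO)[C@@H](O)[C@H]2O)c1O`, is not yet measured. Its change from compound 3 is 2-hydroxy-3-methoxyphenyl in place of 2,3,4-trifluorophenyl on a saturated chain carbon bound to a nitrogen on an aromatic ring. Among the measured compounds shown here, of the measured steps, the one from compound 2 to compound 3 bears most closely, since compound 2 also carries methoxy on its phenyl and sits at the limit. Compound 4 is therefore expected to give a higher number than compound 3, with the step of a 2.1-fold higher number from compound 3 to compound 4 (0.31 log units; beyond the scatter) estimated as modest to large. The estimate for compound 4 in this assay is 120000 nM, within 40000 nM to 300000 nM, with a fair chance that only a limit is reported.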

Compound 4, half-maximal inhibitory concentration: 300 nM
For compound 4 the middle estimate is 400-fold (2.60 log units) above the measured one, and the stated range ends above it.
By their numbers in this assay, from the lowest: compound 4; then compound 1; then compound 3. At a limit, above all of these: compound 2.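

In this assay, among the compounds shown here, the group on a saturated chain carbon bound to a nitrogen on an aromatic ring can take the series well below the earlier compounds: 2-hydroxy-3-methoxyphenyl gives a 190-fold lower number from compound 3 to compound 4 (2.29 log units; beyond the scatter) and a 13-fold lower number from compound 1 to compound 4 (1.10 log units; beyond the scatter). Methoxy on the phenyl therefore does not by itself go with a high number, as an at least 550-fold lower number from compound 2 to compound 4 (2.74 log units; beyond the scatter) shows for 2-hydroxy-3-methoxyphenyl against 3,5-dimethoxyphenyl. That step gives only a lower bound on its size, since compound 2 stands at a limit and not at a number: the limit of > 166000 nM in this assay, at which 1 of the 4 values shown sits.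

Compound 4 brings in hydroxy and methoxy together, and the compounds shown do not separate the two. On these data alone, whether a phenyl with hydroxy alone, or an amine in place of the hydroxy, keeps the low number remains open.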